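Ethoxycarbonyl to Acetyl on Two Related Cores

This account rests on a few compounds, and the source may have more. Where it says the series, first, only, none or still open, it means among the compounds named here.

Measured compounds in a functional assay on OVCAR-3 cells (Homo sapiens) for inhibition, read by sulforhodamine B assay, with a stated time of 48 h; on this read-out lower numbers stand for stronger inhibition of growth and higher numbers for weaker inhibition of growth:
compound 1 `C=C(C)[C@@H]1CC=C(Cn2cc(COc3ccc(C4NC(=O)NC(C)=C4C(=O)OCC)cc3)nn2)CC1`: 6900 nM
compound 2 `C=C(C)[C@@H]1CC=C(Cn2cc(COc3ccccc3C3NC(=O)NC(C)=C3C(=O)OCC)nn2)CC1`: 81200 nM
compound 3 `C=C(C)[C@@H]1CC=C(Cn2cc(COc3ccc(C4NC(=O)NC(C)=C4C(C)=O)cc3)nn2)CC1`: 32700 nM

Compound 1 gives the lowest of the three numbers, and compound 2 stands at the top of the set, with a higher number than compound 3 and a still higher number than compound 1, both gaps beyond the usual scatter. Compound 1 and compound 2 are built from the same atoms joined differently; the difference between the two cores is not broken down here.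

Compound 1 and compound 3 differ in one place only, (methyl in place of ethoxy on a carbonyl carbon), and that change made a 4.7-fold higher number from compound 1 to compound 3 (0.68 log units; beyond the scatter). The unmeasured compound 4 `C=C(C)[C@@H]1CC=C(Cn2cc(COc3ccccc3C3NC(=O)NC(C)=C3C(C)=O)nn2)CC1` is related to compound 2 by the same change, (methyl in place of ethoxy on a carbonyl carbon), at a place described in the same words, so it is the same change carried onto the core of compound 2.

On that basis compound 4 is expected to give a higher number than compound 2, with a step of about a 3.7-fold higher number from compound 2 to compound 4 (0.57 log units; beyond the scatter) in this assay, resting on the size of the step from compound 1 to compound 3 and on the value of compound 2, 81200 nM. The estimate for compound 4 is 300000 nM, with a range from 90000 nM to 900000 nM.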

Compound 4, concentration for total growth inhibition: 34300 nM
Compound 4: middle estimate off by 8.7-fold (0.94 log units), on the high side; measured number outside the range, below it.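

In this assay, methyl in place of ethoxy on a carbonyl carbon gave a 2.4-fold lower number from compound 2 to compound 4 (0.37 log units; beyond the scatter), so the change did not behave on this core as it had on the other, where it raised the number. Set side by side, the two steps run in opposite directions, and the gap between them is larger than the scatter of two such steps would explain: the same change on two cores in this assay, a 4.7-fold higher number (0.68 log units; beyond the scatter) from compound 1 to compound 3 and a 2.4-fold lower number (0.37 log units; beyond the scatter) from compound 2 to compound 4, 11-fold (1.05 log units) apart, beyond the scatter of two such steps

This shows that, for these two pairs, neither the direction nor the size of the ethoxycarbonyl to acetyl step can be carried from one core to the other, so the step measured on one core gives no safe guide to the result on the second; it does not show why the two cores differ, and two pairs cannot establish a rule for any further core in the series.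

The compounds shown leave open how other groups on that carbonyl carbon would behave on the two cores, for instance a longer chain such as propoxy in place of ethoxy, or an amine, which would give an amide. They also leave open whether the reversal would persist with such groups or is confined to the ethoxy and methyl pair.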